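Chloro to trifluoromethyl on the pyridyl ether

The source may report more compounds than this note shows. Statements on the series, on what has been measured and on what is new or still open speak of the compounds shown alone.

Measured so far:
compound 1 `Cn1c(CN2C[C@@H]3C(COc4ccc(Cl)cc4)[C@@H]3C2)nc2ccccc21`: 26 nM
compound 2 `Cn1c(CN2C[C@@H]3C(COc4ccc(C(F)(F)F)cc4)[C@@H]3C2)nc2ccccc21`: 85 nM
compound 3 `Cn1c(CN2C[C@@H]3C(COc4ccc(Cl)cn4)[C@@H]3C2)nc2ccccc21`: 26 nM

All three share the same core and differ only in the aryl ether end. In an in vitro assay on HEK293 cells with metabotropic glutamate receptor 2 (Rattus norvegicus) as the target, read by FLIPR, in the presence of a further agent that is not named here (a higher number here means that more compound is needed for the effect, a lower number that less compound is needed), compound 1 gives 26 nM. The difference from compound 1 to compound 2 is trifluoromethyl in place of chloro on an aromatic carbon and it brings a 3.3-fold higher number from compound 1 to compound 2 (0.51 log units; beyond the scatter). The difference from compound 1 to compound 3 is 5-chloropyridin-2-yl in place of 4-chlorophenyl on an oxygen on a saturated carbon, and here no change at the digits printed from compound 1 to compound 3 (within the scatter), so compound 1 and compound 3 sit together at the low end of the three numbers.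

Compound 4 `Cn1c(CN2C[C@@H]3C(COc4ccc(C(F)(F)F)cn4)[C@@H]3C2)nc2ccccc21` is not yet measured in this assay. Relative to compound 3 the difference is trifluoromethyl in place of chloro on an aromatic carbon. This is the same kind of change as that from compound 1 to compound 2, but the surroundings are not identical: in compound 1 the change sits on a six-membered aromatic ring of carbon only, whereas in compound 3 it sits on a six-membered aromatic ring with 1 nitrogen, two atoms from the ring nitrogen; in both cases para to a large group.

Going by the values given here, the expected step is a 3.3-fold higher number from compound 3 to compound 4 (0.51 log units; beyond the scatter), resting on the single precedent a 3.3-fold higher number from compound 1 to compound 2 (0.51 log units; beyond the scatter) and on the observation that the ring swap gave no change at the digits printed from compound 1 to compound 3 (within the scatter). Compound 4 is therefore estimated at 85 nM, with a range from 35 nM to 200 nM.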

Compound 4, half-maximal effective concentration: 30 nM
The estimate for compound 4 lay 2.8-fold (0.45 log units) above the measured number, and the stated range ends above it.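

In this assay, trifluoromethyl in place of chloro on the six-membered aromatic ring with 1 nitrogen gives a 1.2-fold higher number from compound 3 to compound 4 (0.06 log units; within the scatter), so the two groups cannot be told apart on this ring. The size of this change does not carry over unaltered between the two cores in this series: the same change on two cores in this assay, a 3.3-fold higher number (0.51 log units; beyond the scatter) from compound 1 to compound 2 and a 1.2-fold higher number (0.06 log units; within the scatter) from compound 3 to compound 4, 2.8-fold (0.45 log units) apart, beyond the scatter of two such steps. The ring swap with chloro gave no change at the digits printed from compound 1 to compound 3 (within the scatter), so a matching result for the two chloro compounds did not foretell a matching step for trifluoromethyl, but one pair on each core shows neither why the steps part nor that the ring nitrogen would alter the step for any other group.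

Only chloro and trifluoromethyl are shown at this place, so it stays open whether a nitrile, a methoxy group or an amine would also give steps that part between the two cores. From the compounds shown here alone, it also stays open whether the same parting would appear with a longer chain in place of the ether link, or with a carboxylic acid on the aromatic ring.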